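Working notes: sulfonyl aryl change, compound 2 to compound 3

The source may hold more compounds than are shown below. What is called first, only, known or untested is meant among the compounds shown, and "the series" means these compounds.

Compound 1 `COc1ccc(S(=O)(=O)Nc2ccc(-c3nc4ccccc4o3)cc2)cc1` and compound 2 `Cc1cccc(S(=O)(=O)Nc2ccc(-c3nc4ccccc4o3)cc2)c1` share a core and differ only in the aryl on the sulfonyl sulfur. In an ADME assay on HEK293 cells (Homo sapiens) for cytotoxicity, read by resazurin assay, with a stated time of 48 h (a lower number here means that less compound is tolerated, a higher number that more compound is tolerated), compound 1 gives only a limit, > 100000 nM. Compound 2 likewise gives only a limit in this assay, > 100000 nM. The step that the two limits leave unreadable from compound 1 to compound 2 cannot be sized, since both values sit at the limit of > 100000 nM in this assay, at which 2 of the 2 values shown sit. Compound 2 thus stands at the limit, with no number to place it above or below compound 1.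

Compound 3 `COc1ccccc1S(=O)(=O)Nc1ccc(-c2nc3ccccc3o2)cc1` differs from compound 2 by 2-methoxyphenyl in place of 3-methylphenyl on a sulfonyl sulfur. Going by the values given here, the one measured step bears on this change only in that the earlier swap of the aryl on the sulfonyl sulfur left both compounds at the limit, so no step beyond the scatter in this assay is expected here either. Compound 3 is expected to give 150000 nM in this assay, within a range from 60000 nM to 400000 nM, most likely reported again as a limit. This estimate corresponds to an expected step that the limit leaves unreadable from compound 2 to compound 3.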

Compound 3, half-maximal cytotoxic concentration: > 100000 nM
Compound 3: no number, only a limit; the forecaster's own chance of this, stated with the estimate: 85%; the middle value does not contradict the limit.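

Compound 3, like compound 1 and compound 2, gives only a limit in this assay, so the steps among these three compounds cannot be read: the limit of > 100000 nM in this assay, at which 3 of the 3 values shown sit.

The compounds shown leave open whether any aryl on the sulfonyl sulfur changes the tolerated concentration in this assay.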